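The source may report more compounds than this note shows. Statements on the series, on what has been measured and on what is new or still open speak of the compounds shown alone.

In an ADME assay on A549 cells (Homo sapiens) for cytotoxicity, read by resazurin assay, with a stated time of 48 h (a higher number here means that more compound is tolerated, a lower number that less compound is tolerated), compound 3 `O=C(Nc1ccc(NCc2ccncc2)cc1Cl)c1cc(Cl)ccc1O` gives 65300 nM, the highest of three numbers, compared with compound 1 `CCNc1ccc(NC(=O)c2cc(Cl)ccc2O)c(Cl)c1` at 30200 nM and compound 2 `CCCCCCCCC(C)Nc1ccc(NC(=O)c2cc(Cl)ccc2O)c(Cl)c1` at 21900 nM. Compound 4 `CC(CCO)Nc1ccc(NC(=O)c2cc(Cl)ccc2O)c(Cl)c1` differs from compound 3 in one place: 3-hydroxy-1-methylpropyl in place of (pyridin-4-yl)methyl on a nitrogen on an aromatic ring. Within the data shown here, two measured steps bear on this change. Bringing in the pyridin-4-yl group gave a 2.2-fold higher number from compound 1 to compound 3 (0.33 log units; beyond the scatter), while lengthening the open chain gave a 1.4-fold lower number from compound 1 to compound 2 (0.14 log units; within the scatter). Compound 4 has no ring in this group, so a number back near that of compound 1 at 30200 nM is expected. The expected step in this assay is a 2.2-fold lower number from compound 3 to compound 4 (0.34 log units; beyond the scatter), similar in size to the first of those steps. For compound 4 the estimated value is 30000 nM, with an expected range from 14000 nM to 65000 nM.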

Compound 4, half-maximal cytotoxic concentration: 200000 nM
Compound 4: middle estimate off by 6.7-fold (0.82 log units), on the low side; measured number outside the range, above it.
By their numbers in this assay, from the lowest: compounds 2 and 1 (each within the scatter of the next); then compound 3; then compound 4.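

In this assay, compound 4 is the best tolerated of the four: a 3.1-fold higher number from compound 3 to compound 4 (0.49 log units; beyond the scatter), a 6.6-fold higher number from compound 1 to compound 4 (0.82 log units; beyond the scatter) and a 9.1-fold higher number from compound 2 to compound 4 (0.96 log units; beyond the scatter). On this nitrogen, then, an open chain can go beyond the pyridin-4-yl group, although compound 1 and compound 2, whose chains carry no hydroxy, both stand below compound 3. Nothing measured here explains this rise.

The compounds shown leave open whether the hydroxy group needs this chain length. They also leave open whether an amine or a carboxylic acid in its place would give a similar number.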